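This account rests on a few compounds, and the source may have more. Where it says the series, first, only, none or still open, it means among the compounds named here.

In an in vitro ADME assay on microsomes from liver (Homo sapiens) for metabolic stability, using NADPH, with a stated time of 10 min, tested at 0.5 uM (a higher number here means that the compound lasts longer, a lower number that the compound disappears faster), compound 1 `COc1cc(C2CCN(CC(N)=O)CC2)ccc1Nc1ncc2ccc(-c3ccccc3OC)n2n1` gives > 0.666 h, which is a limit of the assay (the limit of > 0.666 h in this assay, at which 1 of the 2 values shown sits). Replacing one group gives compound 2 `COc1cc(C2CCN(CC(N)=O)CC2)ccc1Nc1ncc2ccc(-c3ccccc3N(C)S(C)(=O)=O)n2n1`. In this assay compound 2 gives < 0.0834 h, also a limit (the limit of < 0.0834 h in this assay, at which 1 of the 2 values shown sits). Among the measured compounds shown here, the step of an at least 7.9-fold lower number from compound 1 to compound 2 (0.90 log units; beyond the scatter) is the only measured change, and it concerns a different group. Compound 3 `COc1cc(C2CCN(CC(N)=O)CC2)ccc1Nc1ncc2c(C)cc(-c3ccccc3N(C)S(C)(=O)=O)n2n1` differs from compound 2 by methyl in place of hydrogen on an aromatic carbon. No measured step involves such a methyl, so no direction can be read from the numbers shown. The step from compound 2 to compound 3 is therefore expected to be a step that the limit leaves unreadable from compound 2 to compound 3. In this assay compound 3 is expected to give about 0.07 h, within 0.03 h to 0.17 h.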

Compound 3, half-life: 0.3 h
Estimate against measurement, compound 3: 4.3-fold (0.63 log units) below; measured number outside the range, above it.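

In this assay, methyl in place of hydrogen on this aromatic carbon of the five-membered ring is the first change shown that raises the number: an at least 3.5-fold higher number from compound 2 to compound 3 (0.55 log units; beyond the scatter). Compound 2 gives < 0.0834 h, which is a limit of the assay. Among the compounds shown here, the only earlier step, an at least 7.9-fold lower number from compound 1 to compound 2 (0.90 log units; beyond the scatter), went the other way and concerned a different group at a different place. The compounds shown leave open whether a longer chain such as ethyl, or a fluorine atom, would do the same at this carbon. They also leave open whether this methyl would act alike with methoxy in place of the methyl(methylsulfonyl)amino group.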